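Ethynyl for phenyl on a nucleoside core: working notes

The compounds below may be only part of what the source reports. "The series", "measured", "known", "first", "only" and "open" are said of these compounds alone.

The series is read in a functional assay on CCRF-CEM cells (Homo sapiens), read by MTT assay, with a stated time of 72 h; on this read-out lower numbers stand for stronger inhibition and higher numbers for weaker inhibition. Compound 3 `CNc1ncnc2c1c(-c1ccccc1)cn2[C@@H]1O[C@H](CO)[C@@H](O)[C@H]1O` gives in this assay only a limit, > 20000 nM. Compound 1 `C#Cc1cn([C@@H]2O[C@H](CO)[C@@H](O)[C@H]2O)c2ncnc(NC)c12` likewise gives only a limit in this assay, namely > 20000 nM. Compound 2 `COc1ncnc2c1c(-c1ccccc1)cn2[C@@H]1O[C@H](CO)[C@@H](O)[C@H]1O` also gives only a limit in this assay, > 20000 nM. For the measured compounds named here, all three values sit at the limit of > 20000 nM in this assay, at which 3 of the 3 values shown sit, so no step among them can be sized. The change from compound 3 to compound 1 is ethynyl in place of phenyl on an aromatic carbon, and the step it made is a step that the two limits leave unreadable from compound 3 to compound 1. The two cores of compound 2 and compound 3 differ as methoxy in place of methylamino on an aromatic carbon, with the step that the two limits leave unreadable from compound 2 to compound 3 between them.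

Compound 4 `C#Cc1cn([C@@H]2O[C@H](CO)[C@@H](O)[C@H]2O)c2ncnc(OC)c12` has not been measured in this assay. It differs from compound 2 by ethynyl in place of phenyl on an aromatic carbon, the same change as that from compound 3 to compound 1, on the same place word for word. Beside that measured step, the expected step from compound 2 to compound 4 in this assay is a step that the limit leaves unreadable from compound 2 to compound 4, which rests on compound 2 showing > 20000 nM and on compound 1 showing > 20000 nM, both limits. Compound 4 is therefore expected to give about 30000 nM in this assay, most likely reported again as a limit, within an estimated range from 15000 nM to 100000 nM.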

Compound 4, half-maximal inhibitory concentration: > 20000 nM
Compound 4: a limit, no number; the forecaster's own chance of this, stated with the estimate: 85%; the middle value is on the limit's open side.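

In this assay compound 4 gives > 20000 nM, which is a limit and not a number. No step can be read from compound 2 to compound 4 or from compound 1 to compound 4, since all the values sit at one limit: the limit of > 20000 nM in this assay, at which 4 of the 4 values shown sit.

Going by these compounds, whether ethynyl in place of phenyl, or methoxy in place of methylamino, changes inhibition on the shared core stays open.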